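Replacing the Difluorophenyl Amide Group of Compound 3

The source may report more compounds than this note shows. Statements on the series, on what has been measured and on what is new or still open speak of the compounds shown alone.

Three compounds share one core and differ only in the aryl group attached to the amide carbonyl carbon. Compound 1 `O=C(Nc1cccc(-c2oc3cc(-c4ccc(F)cc4)ccc3c(=O)c2O)c1)c1ccccc1F` gives 7570 nM in a functional assay on MCF7 cells (Homo sapiens) for antiproliferative activity, read by CCK-8 assay, with a stated time of 72 h; a higher number here means a weaker inhibitor, a lower number a stronger inhibitor. Compound 2 `COc1ccc(C(=O)Nc2cccc(-c3oc4cc(-c5ccc(F)cc5)ccc4c(=O)c3O)c2)cc1` gives 6250 nM in this assay. Compound 3 `O=C(Nc1cccc(-c2oc3cc(-c4ccc(F)cc4)ccc3c(=O)c2O)c1)c1ccc(F)cc1F` gives 13500 nM in this assay. Compound 3 therefore carries the highest of the three numbers, although the step of a 1.8-fold higher number from compound 1 to compound 3 (0.25 log units; within the scatter) is too small to separate it from compound 1 with confidence.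

Compound 4 `O=C(Nc1cccc(-c2oc3cc(-c4ccc(F)cc4)ccc3c(=O)c2O)c1)c1ccc(C(F)(F)F)cc1` differs from compound 3 in one place: 4-(trifluoromethyl)phenyl in place of 2,4-difluorophenyl on a carbonyl carbon. Two measured steps also exchange the aryl group on this carbonyl carbon, and both were small: a 1.2-fold lower number from compound 1 to compound 2 (0.08 log units; within the scatter) and a 2.2-fold higher number from compound 2 to compound 3 (0.33 log units; beyond the scatter). Every such exchange so far has moved the number only modestly, so the step of a 1.5-fold lower number from compound 3 to compound 4 (0.18 log units; within the scatter) is expected to be of similar size, with no clear direction. Compound 4 is accordingly estimated at 9000 nM in this assay, with a likely range from 4000 nM to 20000 nM.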

Compound 4, half-maximal inhibitory concentration: 32600 nM
Estimate against measurement, compound 4: 3.6-fold (0.56 log units) below; measured number above the stated range.
By their numbers in this assay, from the lowest: compounds 2, 1 and 3 (each within the scatter of the next, the first and the last beyond it); then compound 4.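

The aryl group on this carbonyl carbon is not as interchangeable as the earlier exchanges suggested, since 4-(trifluoromethyl)phenyl gives a step beyond the scatter in this assay (2,4-difluorophenyl leaving: a 2.4-fold higher number from compound 3 to compound 4 (0.38 log units; beyond the scatter)). The steps from the other two aryl groups are larger still (a 4.3-fold higher number from compound 1 to compound 4 (0.63 log units; beyond the scatter); a 5.2-fold higher number from compound 2 to compound 4 (0.72 log units; beyond the scatter)), the biggest being trifluoromethyl in place of methoxy, which makes compound 4 the weakest inhibitor of the four. No measurement shown gives a reason for this loss.

Still open, on these data alone, is how this position responds to groups unlike any of these aryl rings, such as an amine or a carboxylic acid on the ring, or a cyclohexyl ring in place of it. As far as these compounds go, it is also open whether any group here can bring the number clearly below that of compound 2.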